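A few compounds are considered here, and "the series" means these few. Any claim that something is new, unique, unknown or untested is made for them only; others in the source may bear on it.

Working notes on the series, read in an ADME assay on HCT-116 cells (Homo sapiens) for cytotoxicity, read by CellTiter-Glo, with a stated time of 72 h; a higher number here means a weaker inhibitor, a lower number a stronger inhibitor.

Compound 1 `CC1CCN(C2CCN(S(=O)(=O)c3cccc(C(F)(F)F)c3)CC2)CC1` gives > 5000 nM in this assay, which is a limit of the measurement rather than a number. Compound 2 `Cc1cc(C)c(S(=O)(=O)N2CCN(C3CCN(C)CC3)CC2)c(C)c1` likewise reaches only the limit > 5000 nM in this assay. Compound 3 `COc1ccc(NC(=O)N2CCC(N3CCC(C)CC3)CC2)cc1` also sits at a limit, > 5000 nM in this assay. Across the three measured compounds the only evidence is therefore (the limit of > 5000 nM in this assay, at which 3 of the 3 values shown sit); no step between measured compounds can be sized, and compound 1 stands level with the others at that limit.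

Compound 4 `CC1CCN(C2CCN(S(=O)(=O)c3cccc(-c4ccccc4C(F)(F)F)c3)CC2)CC1` is the next compound to be measured in this assay. Relative to compound 1 the change is 2-(trifluoromethyl)phenyl in place of trifluoromethyl on an aromatic carbon. With every measured value resting at a limit, no step beyond the scatter is expected in this assay from this change, and the step from compound 1 to compound 4 is expected to be a step that the limit leaves unreadable from compound 1 to compound 4. Compound 4 is accordingly estimated to give about 6000 nM in this assay, within a range from 2000 nM to 20000 nM, most likely again reported as a limit.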

Compound 4, half-maximal inhibitory concentration: > 5000 nM
Compound 4: a limit, no number (the forecaster's own chance of this, stated with the estimate: 70%); the middle value does not contradict the limit.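

No step can be read from compound 1 to compound 4, since both rest at a limit in this assay: the limit of > 5000 nM in this assay, at which 4 of the 4 values shown sit.

The compounds shown leave open whether any of them has a readable half-maximal inhibitory concentration in this assay, and what 2-(trifluoromethyl)phenyl in place of trifluoromethyl does to it.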